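This account rests on a few compounds, and the source may have more. Where it says the series, first, only, none or still open, it means among the compounds named here.

Compound 1 `O=C(/C=C\Nc1ccc(C(F)(F)F)cc1)c1cn(-c2ccccc2)nc1-c1ccccc1` — in a functional assay on PC-3 cells (Homo sapiens) for antiproliferative activity, read by MTT assay, with a stated time of 48 h (on this read-out higher numbers stand for weaker inhibition and lower numbers for stronger inhibition), compound 1 gives > 50000 nM, a limit of the assay.
Compound 2 `COc1ccc(-c2nn(-c3ccccc3)cc2C(=O)/C=C\Nc2ccc(C(F)(F)F)cc2)cc1` — compound 2 gives > 50000 nM, again a limit of the assay.
Compound 3 `COc1ccc(-c2nn(-c3ccccc3)cc2C(=O)/C=C\Nc2ccc(O)cc2)cc1` — compound 3 gives 1980 nM.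

Compound 2 thus stands at the limit of > 50000 nM in this assay, at which 2 of the 3 values shown sit, and has no number of its own, only a limit. Compound 4 `COc1cc(-c2nn(-c3ccccc3)cc2C(=O)/C=C\Nc2ccc(C(F)(F)F)cc2)cc(OC)c1OC` differs from it in one place: 3,4,5-trimethoxyphenyl in place of 4-methoxyphenyl on an aromatic carbon.

Two measured steps exist. The first, a step that the two limits leave unreadable from compound 1 to compound 2, is the only one that touches the same aromatic carbon of the core, and it cannot be read because both ends sit at the limit. The second, an at least 25-fold lower number from compound 2 to compound 3 (1.40 log units; beyond the scatter), is large, but it concerns a different place, where hydroxy replaces trifluoromethyl, and compound 4 keeps the trifluoromethyl of compound 2. Nothing shown therefore supports expecting a step beyond the scatter from compound 2 to compound 4 in this assay.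

Compound 4 is expected to stay near the limit, estimated at 60000 nM in this assay, in the range 15000 nM to 200000 nM, which means an expected step that the limit leaves unreadable from compound 2 to compound 4.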

Compound 4, half-maximal inhibitory concentration: > 50000 nM
Compound 4 gave a limit, no number (the forecaster's own chance of this, stated with the estimate: 75%); the middle value does not contradict the limit.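

Compound 4 gives a limit and no number, as do compound 1 and compound 2, so no step among these three can be read in this assay: the limit of > 50000 nM in this assay, at which 3 of the 4 values shown sit.

The compounds shown leave open whether 3,4,5-trimethoxyphenyl differs at all from 4-methoxyphenyl once hydroxy replaces trifluoromethyl, as in compound 3.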